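The source may report more compounds than this note shows. Statements on the series, on what has been measured and on what is new or still open speak of the compounds shown alone.

Three compounds built on one shared core differ only in where a chlorine sits on a benzyl group. Compound 1 `O=S(=O)(NCCCNCc1ccc(Cl)cc1)c1cc(C(F)(F)F)cc(C(F)(F)F)c1` gives 2400 nM in a functional assay on MCF7 cells (Homo sapiens) for inhibition, read by MTT assay, with a stated time of 72 h (on this read-out lower numbers stand for stronger inhibition of growth and higher numbers for weaker inhibition of growth), compound 2 `O=S(=O)(NCCCNCc1cccc(Cl)c1)c1cc(C(F)(F)F)cc(C(F)(F)F)c1` gives 2600 nM, and compound 3 `O=S(=O)(NCCCNCc1ccccc1Cl)c1cc(C(F)(F)F)cc(C(F)(F)F)c1` gives 8800 nM. Compound 3 therefore has the highest number of the three, with a 3.7-fold higher number from compound 1 to compound 3 (0.56 log units; beyond the scatter) and a 3.4-fold higher number from compound 2 to compound 3 (0.53 log units; beyond the scatter), while a 1.1-fold higher number from compound 1 to compound 2 (0.03 log units; within the scatter).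

Compound 4 `CN(CCCNS(=O)(=O)c1cc(C(F)(F)F)cc(C(F)(F)F)c1)Cc1ccccc1` is not yet measured. Its structure differs from compound 3 by benzyl(methyl)amino in place of (2-chlorobenzyl)amino on a saturated chain carbon, three bonds along the chain from a sulfonamide nitrogen. The chlorine is thus removed altogether, and at the same time the amine hydrogen is replaced by a methyl group.

The two measured steps that bear on this are the steps from compound 1 to compound 3 and from compound 2 to compound 3, both modest rises in the number when the chlorine moves to the 2-position. Removing that chlorine might be expected to undo part of that rise. Among the measured compounds shown here, no measured pair speaks to the methyl group on the amine nitrogen, so that part of the change is an open question. On balance a modest fall is expected, a 2.0-fold lower number from compound 3 to compound 4 (0.29 log units; within the scatter), giving compound 4 an estimated 4500 nM in this assay, within a range from 1500 nM to 13000 nM.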

Compound 4, concentration for 50% growth inhibition: 16000 nM
Compound 4: the middle estimate sits 3.6-fold (0.55 log units) below what was measured; measured number outside the range, above it.
By their numbers in this assay, from the lowest: compounds 1 and 2 (each within the scatter of the next); then compounds 3 and 4 (each within the scatter of the next).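

The swap of (2-chlorobenzyl)amino for benzyl(methyl)amino in this assay leaves compound 4 within the scatter of compound 3 (a 1.8-fold higher number from compound 3 to compound 4 (0.26 log units; within the scatter)), so removing the chlorine from this benzyl group does not, in this combined change, bring the number back towards those of the compounds with chlorine elsewhere on the ring. Compound 4 instead stays clearly weaker than both of those compounds (a 6.2-fold higher number from compound 2 to compound 4 (0.79 log units; beyond the scatter); a 6.7-fold higher number from compound 1 to compound 4 (0.82 log units; beyond the scatter)), which shows that a benzyl group with no chlorine at all gives no advantage here when the amine nitrogen also carries a methyl group. No measurement available here explains this result.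

Because the chlorine left and the methyl group arrived in the same step, the compounds shown cannot say how much each change contributes. The plain benzylamino group, with no chlorine and with the amine hydrogen kept, would isolate the chlorine, while the (4-chlorobenzyl)(methyl)amino group would show what the methyl group does on the better of the chlorinated compounds' shared level.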